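The compounds below may be only part of what the source reports. "The series", "measured", "known", "first", "only" and "open" are said of these compounds alone.

Compound 1 `CCCCC1=Nc2ccccc2S(=O)(=O)N1Cc1ccc(-c2ccccc2C(=O)O)cc1` gives 160 nM in a functional assay (aorta) for antagonist activity, with Oryctolagus cuniculus as the target; a higher number here means a weaker inhibitor, a lower number a stronger inhibitor; compound 3 `CCCCC1=NS(=O)(=O)c2ccccc2N1Cc1ccc(-c2ccccc2C(=O)O)cc1` gives 130 nM; compound 2 `CCCSC1=NS(=O)(=O)c2ccc(C(=O)O)cc2N1Cc1ccc(-c2ccccc2-c2nn[nH]n2)cc1` gives 0.08 nM.

Compound 1 and compound 3 sit within the scatter of each other in this assay, while compound 2 lies far below both, beyond the scatter. Compound 4 `CCCSC1=Nc2ccccc2S(=O)(=O)N1Cc1ccc(-c2ccccc2C(=O)O)cc1` differs from compound 1 in one place: propylsulfanyl in place of butyl on a carbon with a double bond to nitrogen. Within the data shown here, no measured pair shows this change on its own. Compound 2 also carries a propylsulfanyl group, but its other differences from compound 1 are too many to attribute its value to that group. A modest step toward a lower number is expected for compound 4, roughly a 2.0-fold lower number from compound 1 to compound 4 (0.30 log units; within the scatter), near the edge of the scatter. Compound 4 is therefore estimated at 80 nM, with a range of 20 nM to 300 nM.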

Compound 4, antagonist equilibrium constant: 1200 nM
The estimate for compound 4 lay 15-fold (1.18 log units) below the measured number; measured number outside the range, above it.
By their numbers in this assay, from the lowest: compound 2; then compounds 3 and 1 (each within the scatter of the next); then compound 4.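

In this assay, among these compounds, propylsulfanyl in place of butyl on this carbon gives a 7.5-fold higher number from compound 1 to compound 4 (0.88 log units; beyond the scatter), the only step here that isolates a single change, and it makes compound 4 a weaker inhibitor. Both groups have 4 heavy atoms, so that count alone does not set the number at this position. Nothing available here gives a reason for the step. From the compounds shown here alone, it remains open whether a propoxy or pentyl group on this carbon would move the number in the same direction, and whether the step would hold in another core.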